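Notes on amide chain length across four compounds

The compounds below may be only part of what the source reports. "The series", "measured", "known", "first", "only" and "open" are said of these compounds alone.

Compound 1 `CCCCCCCCCCCCCCCCCC(=O)Nc1nnc(S[C@@H]2O[C@H](COC(C)=O)[C@H](OC(C)=O)[C@H](OC(C)=O)[C@H]2OC(C)=O)s1` and compound 2 `CCCCCCCC/C=C\CCCCCCCC(=O)Nc1nnc(S[C@@H]2O[C@H](COC(C)=O)[C@H](OC(C)=O)[C@H](OC(C)=O)[C@H]2OC(C)=O)s1` carry long acyl chains on the shared core; in a functional assay on SK-OV-3 cells (Homo sapiens) for cytotoxicity, read by MTT assay, with a stated time of 24 h (a lower number here means a stronger inhibitor, a higher number a weaker inhibitor), compound 1 gives "not active" (no number reported) and compound 2 gives "not active" (no number reported), so neither yields a number. Within the data shown here, compound 3 `CCCCCCCC(=O)Nc1nnc(S[C@@H]2O[C@H](CO)[C@H](O)[C@H](O)[C@H]2O)s1`, with a shorter chain, gives 56000 nM in this assay, the only numerical value in the set, and so stands as the sole point of reference; it sits at the weak end of what the assay reports. Compound 4 `C=CCCCCCCCCC(=O)Nc1nnc(S[C@@H]2O[C@H](CO)[C@H](O)[C@H](O)[C@H]2O)s1` differs from compound 3 by allyl in place of hydrogen on a saturated chain carbon, seven bonds along the chain from a carbonyl carbon. Among the measured compounds shown here, no step between measured compounds exists, so the expectation rests on compound 3 alone: a small step, a slight loss or none beyond the scatter, is expected in this assay. The expected step is a 1.3-fold higher number from compound 3 to compound 4 (0.10 log units; within the scatter). For compound 4 the estimate is 70000 nM, between 25000 nM and 200000 nM.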

Compound 4, half-maximal inhibitory concentration: "not active" (no number reported)
No number was reported for compound 4, and the estimate cannot be compared.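

Among these compounds, compound 4 gives no number in this assay and so no step from compound 3 to compound 4 can be read. No supporting data bear on this result. The compounds shown leave open how amide chain length relates to the read-out.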